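Anilinothiazole series: amino in place of fluoro at compound 2

A few compounds are considered here, and "the series" means these few. Any claim that something is new, unique, unknown or untested is made for them only; others in the source may bear on it.

Measured so far in an assay on isolated protein for inhibition of Polyunsaturated fatty acid 5-lipoxygenase (Homo sapiens), with stated times of 15 min and 10 min; on this read-out higher numbers stand for weaker inhibition and lower numbers for stronger inhibition:
compound 1 `FC(F)(F)c1ccc(Nc2nc(-c3ccc(Cl)cc3)cs2)cc1` gives 5900 nM
compound 2 `Oc1ccc(Nc2nc(-c3ccc(F)cc3)cs2)cc1` gives 700 nM
compound 3 `Oc1cccc(Nc2nc(-c3ccc(Cl)cc3)cs2)c1` gives 5600 nM

Compound 2 stands lowest of the three numbers in this assay. Compound 3 is the nearest to it, and its number lies beyond the scatter above that of compound 2; compound 1 is the furthest, also beyond the scatter above compound 2. Compound 2 is thus the strongest inhibitor among the three on this read-out.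

Compound 4 `Nc1ccc(-c2csc(Nc3ccc(O)cc3)n2)cc1` differs from compound 2 in one place: amino in place of fluoro on an aromatic carbon. Within the data shown here, no pair among the measured compounds isolates this change, so its size cannot be read from a measured step. The working expectation is a small shift in this assay, more likely toward a somewhat higher number than a lower one, and possibly none beyond the scatter; the expected step of a 1.6-fold higher number from compound 2 to compound 4 (0.20 log units; within the scatter) is set accordingly. For compound 4 the estimate in this assay is 1100 nM, with a range from 300 nM to 4000 nM.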

Compound 4, half-maximal inhibitory concentration: 4400 nM
Compound 4: the middle estimate sits 4.0-fold (0.60 log units) below what was measured; measured number outside the range, above it.
By their numbers in this assay, from the lowest: compound 2; then compounds 4, 3 and 1 (each within the scatter of the next).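

In this assay, amino in place of fluoro on an aromatic carbon, para to a large group, gives a 6.3-fold higher number from compound 2 to compound 4 (0.80 log units; beyond the scatter) and so shows that this position is sensitive to the group it carries. The earlier compounds shown here differ from one another in more than one place and could not isolate any single change. Amino adds a hydrogen-bond donor and a hydrogen-bond acceptor where fluoro has none, but no measurement given here connects that difference with the step.

From the compounds shown here alone, it remains open whether the loss follows amino specifically or any replacement of fluoro, which a methoxy, dimethylamino or acetamide group at this place would help to separate. Going by these compounds, it is also open whether the same step would appear with the hydroxyl moved or replaced on the other aromatic ring.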